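This account rests on a few compounds, and the source may have more. Where it says the series, first, only, none or still open, it means among the compounds named here.

Measured compounds:
Compound 1, `O=C1Nc2ccc(OCc3ccc(Cl)c(Cl)c3)cc2C1=O`: 95.7%
Compound 2, `CC(C)=C1C(=O)Nc2ccc(OCc3cccc(C)c3)cc21`: "not active" (no number reported)

In an assay on cells for inhibition of Amine oxidase [flavin-containing] B (Homo sapiens), read by fluorescence, with stated times of 30 min and 15 min, tested at 1 uM (a higher number here means more inhibition at the concentration tested (going by the name of the read-out), a lower number less inhibition), compound 1 gives 95.7%, a strong response at the single concentration tested. In this assay compound 2 gives "not active" (no number reported): it was reported as not active, so no number stands for it, and its place on the scale is only that it showed no meaningful inhibition.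

Compound 3, `CC(C)=C1C(=O)Nc2ccc(OCCc3ccccc3)cc21`, is the next compound. It is related to compound 2 by a single change: benzyl in place of 3-methylphenyl on a saturated chain carbon bound to an oxygen on an aromatic ring. The two have the same atoms, joined differently. Within the data shown here, no measured step exists between compound 2 and compound 3, so the size of the change can only be guessed. With compound 2 reported as not active, the reasonable expectation is that the number for compound 3 remains low as well, and any difference would likely lie within the usual scatter of the assay. Compound 3 is therefore estimated at 10%, with a range from 0% to 35%.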

Compound 3, a percentage reported as inhibition, at one concentration (the size of the read-out at that concentration, not a potency): "not active" (no number reported)
Compound 3 has no reported number here, so the estimate cannot be set against anything.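

Compound 2 and compound 3 are both reported as not active, with no number for either, so no step can be read between them. Nothing shown here offers an explanation for this result. On these data alone, whether exchanging 3-methylphenyl for benzyl changes inhibition at all stays open.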